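The source may hold more compounds than are shown below. What is called first, only, known or untested is meant among the compounds shown, and "the series" means these compounds.

Of the compounds shown here, three sharing one core have been measured in a functional assay on PC-3 cells (Homo sapiens) for cytotoxicity, read by MTT assay, with a stated time of 48 h; a higher number here means a weaker inhibitor, a lower number a stronger inhibitor. Compound 1 `COc1cc(-c2nnc3n2NC(c2ccco2)C(C(=O)c2ccc(F)c(F)c2)S3)cc(OC)c1OC` gives 36000 nM, compound 2 `COc1cc(-c2nnc3n2NC(c2ccco2)C(C(=O)c2cccs2)S3)cc(OC)c1OC` gives 46200 nM, and compound 3 `COc1cc(-c2nnc3n2NC(c2cccs2)C(C(=O)c2ccc(Cl)cc2)S3)cc(OC)c1OC` gives 32500 nM. Compound 2 holds the highest of the three numbers, yet the step of a 1.3-fold higher number from compound 1 to compound 2 (0.11 log units; within the scatter) and its gap to compound 3 both lie within the scatter, so the three cannot be told apart. Compound 4 `COc1cc(-c2nnc3n2NC(c2ccco2)C(C(=O)c2ccccc2C)S3)cc(OC)c1OC` differs from compound 2 in one place: 2-methylphenyl in place of thiophen-2-yl on a carbonyl carbon. Among the measured compounds shown here, the only measured step at that same carbonyl carbon, a 1.3-fold higher number from compound 1 to compound 2 (0.11 log units; within the scatter), stayed within the scatter, so no step beyond the scatter in this assay is expected from this change either. Compound 4 is therefore estimated at 40000 nM, within 20000 nM to 80000 nM, which would mean a 1.2-fold lower number from compound 2 to compound 4 (0.06 log units; within the scatter).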

Compound 4, half-maximal inhibitory concentration: 88400 nM
The estimate for compound 4 lay 2.2-fold (0.34 log units) below the measured number; measured number outside the range, above it.
By their numbers in this assay, from the lowest: compounds 3, 1, 2 and 4 (each within the scatter of the next, the first and the last beyond it).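

Among the compounds shown here, at the carbonyl carbon, 2-methylphenyl yields the first step in this assay that clears the scatter, though against only one of the two groups compared: the step to it from 3,4-difluorophenyl (a 2.5-fold higher number from compound 1 to compound 4 (0.39 log units; beyond the scatter)) lies beyond the scatter, whereas the step from thiophen-2-yl (a 1.9-fold higher number from compound 2 to compound 4 (0.28 log units; within the scatter)) stays within it. This position therefore responds modestly to the group it carries, a response the earlier pair did not reveal. No evidence available here accounts for the step. Still open, from the compounds shown here alone, is how compound 4 would compare with a close analogue carrying plain phenyl, or an amine or carboxylic acid on that ring, at this carbonyl carbon.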